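The source may hold more compounds than are shown below. What is called first, only, known or untested is meant among the compounds shown, and "the series" means these compounds.

Working notes on the series. Compound 1 `Nc1cc(N)c2nc(-c3ccccc3)c(NCc3ccc(Cl)c(Cl)c3)nc2c1` is the reference point: in a functional assay on NCI-H522 cells (Homo sapiens) for inhibition, read by sulforhodamine B assay, with a stated time of 48 h (on this read-out higher numbers stand for weaker inhibition of growth and lower numbers for stronger inhibition of growth), compound 1 gives 4900 nM. Compound 2 `COc1ccc(CNc2nc3cc(N)cc(N)c3nc2-c2ccccc2)cc1OC` differs only in the aryl substituents of the benzylic arm, and in this assay compound 2 gives 6310 nM; the step of a 1.3-fold higher number from compound 1 to compound 2 (0.11 log units; within the scatter). Compound 3 `Nc1cc(N)c2nc(-c3ccccc3)c(NCc3ccc(F)cc3)nc2c1` carries the 4-fluorophenyl variant of the same arm. For compound 3 the result in this assay is a limit only, < 100000 nM, which is the limit of < 100000 nM in this assay, at which 1 of the 3 values shown sits. Hence a step that the limit leaves unreadable from compound 1 to compound 3 and likewise a step that the limit leaves unreadable from compound 2 to compound 3. Compound 3 therefore stands on this read-out without a number to compare.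

Compound 4 `Nc1cc(N)c2nc(-c3ccccc3)c(Oc3ccc(F)cc3)nc2c1` is the next step from compound 3: 4-fluorophenoxy in place of (4-fluorobenzyl)amino on an aromatic carbon. Among the measured compounds shown here, no measured step exchanges the amino link for an oxygen link; the one readable step, a 1.3-fold higher number from compound 1 to compound 2 (0.11 log units; within the scatter), concerns only the aryl substituents, and the two steps into compound 3 have no readable size. The expectation for compound 4 rests on compound 1, which gives 4900 nM, and on compound 2, which gives 6310 nM. Those two numbers sit close together, so compound 4 is expected near that range, with wide uncertainty. The step that the limit leaves unreadable from compound 3 to compound 4 is the estimated consequence, measured against a limit. Compound 4 is expected at 12000 nM, within 2500 nM to 60000 nM.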

Compound 4, concentration for total growth inhibition: < 100000 nM
Compound 4: no number, only a limit (the forecaster's own chance of this, stated with the estimate: 30%); the middle value does not contradict the limit.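

Compound 3 and compound 4 both rest on a limit and not on a number, so no step between them can be read: the limit of < 100000 nM in this assay, at which 2 of the 4 values shown sit.

The compounds shown leave open how 4-fluorophenoxy and (4-fluorobenzyl)amino on the shared core compare in size of effect in this assay.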